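The source may report more compounds than this note shows. Statements on the series, on what has been measured and on what is new or still open speak of the compounds shown alone.

Compound 1 `CCCCCCCCOC(=O)CCC(=O)N1CCN(CCCOc2cc3c(Nc4ccc(F)c(Cl)c4)ncnc3cc2OC)CC1`: 80%. Compound 2 `CCCCCCCCCOC(=O)CCC(=O)N1CCN(CCCOc2cc3c(Nc4ccc(F)c(Cl)c4)ncnc3cc2OC)CC1`: 79.7%. Compound 3 `CCCCCCCCCCCCCCCCOC(=O)CCC(=O)N1CCN(CCCOc2cc3c(Nc4ccc(F)c(Cl)c4)ncnc3cc2OC)CC1`: 91.7%.

These three share one core and differ only in the length of a saturated chain. In a functional assay on A549 cells (Homo sapiens) for cytotoxicity, read by MTT assay, with a stated time of 24 h, tested at 20 uM (a lower number here means a stronger effect, a higher number a weaker effect of the compound at the concentration tested), the change from compound 1 to compound 2 is methyl in place of hydrogen on a saturated chain carbon, eight bonds along the chain from an oxygen next to a carbonyl group, and it brought a number 0.3 percentage points lower from compound 1 to compound 2 (within the scatter). Compound 4 `CCCCCCCCCCCCCCCCCOC(=O)CCC(=O)N1CCN(CCCOc2cc3c(Nc4ccc(F)c(Cl)c4)ncnc3cc2OC)CC1` differs from compound 3 by methyl in place of hydrogen on a saturated chain carbon, ten or more bonds along the chain from an oxygen next to a carbonyl group. Compound 3 itself differs from compound 1 by octyl in place of hydrogen on a saturated chain carbon, eight bonds along the chain from an oxygen next to a carbonyl group, so the two places are not identical: the distance along the chain from the oxygen next to the carbonyl group is not the same in the first pair as in the second. The change is therefore the same kind of change, not the same. Because a number 0.3 percentage points lower from compound 1 to compound 2 (within the scatter) lay within the scatter, compound 4 is expected to move little, by a number 0.3 percentage points higher from compound 3 to compound 4 (within the scatter). In this assay compound 4 is estimated at 92%.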

Compound 4, a percentage reported as activity, at one concentration (the size of the read-out at that concentration, not a potency): 97.2%
Compound 4: middle estimate off by 5.2 percentage points, on the low side; low and high end bracket the measured number.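

In this assay, among the compounds shown here, the single methyl gave a number 5.5 percentage points higher from compound 3 to compound 4 (within the scatter), and this step matches the earlier methyl step: the same change on two cores in this assay, a number 0.3 percentage points lower (within the scatter) from compound 1 to compound 2 and a number 5.5 percentage points higher (within the scatter) from compound 3 to compound 4, 5.8 percentage points apart, within the scatter of two such steps. The octyl change gave a number 17.5 percentage points higher from compound 2 to compound 4 (beyond the scatter), which agrees with its earlier counterpart: the same change on two cores in this assay, a number 11.7 percentage points higher (beyond the scatter) from compound 1 to compound 3 and a number 17.5 percentage points higher (beyond the scatter) from compound 2 to compound 4, 5.8 percentage points apart, within the scatter of two such steps. The nonyl change gave a number 17.2 percentage points higher from compound 1 to compound 4 (beyond the scatter) and has no counterpart here, so these few pairs show only that step sizes held among these closely related chain compounds, not that the changes would carry over to a different core.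

All the compounds shown carry a plain saturated chain. This leaves open how a shorter chain such as butyl, or a chain ending in an amine or a carboxylic acid, would read in this assay.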